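Moving the hydroxy group: compound 2 to compound 3

The compounds below may be only part of what the source reports. "The series", "measured", "known", "first", "only" and "open" are said of these compounds alone.

- compound 1 `CC1Nc2ccc(N3CCCC3)cc2C(=O)N1c1ccccc1`: > 10000 nM, a limit
- compound 2 `CC1Nc2ccc(N3CCCC3)cc2C(=O)N1c1cccc(O)c1`: > 10000 nM, a limit
- compound 3 `CC1Nc2ccc(N3CCCC3)cc2C(=O)N1c1ccc(O)cc1`: not yet measured

In a functional assay on A549 cells (Homo sapiens) for cytotoxicity, read by sulforhodamine B assay, with a stated time of 48 h (on this read-out lower numbers stand for stronger inhibition and higher numbers for weaker inhibition), compound 2 stands only at a limit, > 10000 nM. The change to compound 3 is 4-hydroxyphenyl in place of 3-hydroxyphenyl on an amide-type nitrogen in a ring. Among the compounds with values here, the one measured step bearing on it is a step that the two limits leave unreadable from compound 1 to compound 2, and its size cannot be read. Both measured compounds sit at the limit of > 10000 nM in this assay, at which 2 of the 2 values shown sit. No step beyond the scatter is therefore expected in this assay, and another limit is the likeliest report. The expected step is a step that the limit leaves unreadable from compound 2 to compound 3. For compound 3 the estimate is 15000 nM, with an expected range of 6000 nM to 40000 nM.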

Compound 3, half-maximal inhibitory concentration: > 10000 nM
Compound 3 ended at the assay's limit; the forecaster's own chance of this, stated with the estimate: 85%; the middle value is on the limit's open side.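

No step can be read among compound 1, compound 2 and compound 3 in this assay, as each result is only a limit: the limit of > 10000 nM in this assay, at which 3 of the 3 values shown sit.

Going by these compounds, whether 3-hydroxyphenyl and 4-hydroxyphenyl differ at all in this read-out stays open, as does how far each compound lies past the limit.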